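The source may report more compounds than this note shows. Statements on the series, on what has been measured and on what is new or still open speak of the compounds shown alone.

The measured compounds:

Compound 1 `COc1ccc(CN(c2cc(OC)c(OC)c(OC)c2)S(=O)(=O)c2ccc(C)cc2)cc1`: in a functional assay on MCF7 cells (Homo sapiens) for inhibition, read by MTT assay, with a stated time of 48 h (on this read-out higher numbers stand for weaker inhibition and lower numbers for stronger inhibition), compound 1 gives 10100 nM.
Compound 2 `COc1cc(N(Cc2ccc(F)cc2)S(=O)(=O)c2ccc(C)cc2)cc(OC)c1OC`: in this assay compound 2 gives 19200 nM.
Compound 3 `Cc1ccc(S(=O)(=O)N(Cc2nc3ccccc3[nH]2)c2ccc(F)cc2)cc1`: in this assay compound 3 gives > 50000 nM, which is a limit of the assay and not a number.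

Compound 3 therefore stands apart from the other two: compounds 1 and 2 give numbers, whereas compound 3 reaches only the limit described by the limit of > 50000 nM in this assay, at which 1 of the 3 values shown sits, so its true value is not known.

Compound 4 `Cc1ccc(N(Cc2nc3ccccc3[nH]2)S(=O)(=O)c2ccc(C)cc2)cc1` has not yet been measured in this assay. It differs from compound 3 in one place: methyl in place of fluoro on an aromatic carbon. Among the measured pairs, only one single-point change is shown, a 1.9-fold higher number from compound 1 to compound 2 (0.28 log units; within the scatter), and that change swaps fluoro for methoxy rather than methyl for fluoro, so it does not bear directly on the step from compound 3 to compound 4. Among the compounds with values here, the only step available, a small change on an aromatic ring, stayed within the scatter; nothing in the data suggests that a methyl in place of fluoro would move compound 4 away from where compound 3 sits.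

Compound 4 is therefore expected to sit near the limit, with the step estimated as a step that the limit leaves unreadable from compound 3 to compound 4. For compound 4 the expected value in this assay is 70000 nM, with a range from 30000 nM to 200000 nM, and a considerable chance that the assay again reports only a limit.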

Compound 4, half-maximal inhibitory concentration: > 50000 nM
Compound 4 gave a limit, no number; the forecaster's own chance of this, stated with the estimate: 70%; the middle value is on the limit's open side.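

In this assay compound 4 gives > 50000 nM, which is a limit of the assay and not a number. Compound 3 stands at the same limit, so no step between compound 3 and compound 4 can be read: the limit of > 50000 nM in this assay, at which 2 of the 4 values shown sit.

The compounds shown leave open whether methyl in place of fluoro changes the true value in this assay at all.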